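Compound 3: thiophen-2-yl in place of 4-fluorophenyl

The compounds below may be only part of what the source reports. "The series", "measured", "known", "first", "only" and "open" are said of these compounds alone.

In a functional assay on LN-229 cells (Homo sapiens) for antiproliferative activity, with a stated time of 72 h (on this read-out higher numbers stand for weaker inhibition and lower numbers for stronger inhibition), compound 1 `Nc1ncnn2c([C@@H]3O[C@H](CO)[C@@H](O)[C@H]3O)cc(C#CC3CC3)c12` gives 30 nM. Compound 2 `Nc1ncnn2c([C@@H]3O[C@H](CO)[C@@H](O)[C@H]3O)cc(C#Cc3ccc(F)cc3)c12` gives > 100000 nM, which is a limit of the assay and not a number. Compound 3 `Nc1ncnn2c([C@@H]3O[C@H](CO)[C@@H](O)[C@H]3O)cc(C#Cc3cccs3)c12` has thiophen-2-yl in place of 4-fluorophenyl on a triple-bonded carbon. Among the compounds with values here, one measured step bears on this change: an at least 3300-fold higher number from compound 1 to compound 2 (3.52 log units; beyond the scatter), a large step beyond the scatter, with 4-fluorophenyl in place of cyclopropyl on the same carbon. Within the data shown here, no measured compound carries thiophen-2-yl, so the size of the next step is poorly defined. Since compound 3 also has an aromatic ring there, it is expected to stay closer to compound 2 than to compound 1, with a move towards stronger inhibition or no measurable change. The estimated step is an at least 12-fold lower number from compound 2 to compound 3 (1.09 log units; beyond the scatter). Compound 3 is estimated at 8000 nM, with an expected range of 500 nM to 100000 nM.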

Compound 3, half-maximal inhibitory concentration: > 100000 nM
Compound 3 gave a limit, no number; the forecaster's own chance of this, stated with the estimate: 45%; middle value at least 12-fold (1.09 log units) away from the limit.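

In this assay, cyclopropyl to thiophen-2-yl on a triple-bonded carbon gives an at least 3300-fold higher number from compound 1 to compound 3 (3.52 log units; beyond the scatter), a large step of the same printed size as an at least 3300-fold higher number from compound 1 to compound 2 (3.52 log units; beyond the scatter). The loss of inhibition at this position is therefore not confined to 4-fluorophenyl: a five-membered aromatic ring with a sulfur atom, with fewer heavy atoms than 4-fluorophenyl, also falls far from compound 1. The step between compound 2 and compound 3 cannot be read, because both stand at a limit of the assay: the limit of > 100000 nM in this assay, at which 2 of the 3 values shown sit.

On these data alone, whether the loss follows from having an aromatic ring at all, or also extends to non-aromatic groups, remains open. As far as these compounds go, how a butyl chain or a dimethylaminomethyl group on this carbon would read in this assay is unknown, as is any order among aromatic groups.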